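Sulfonyl aryl swap on the shared core: compound 2 to compound 4

A few compounds are considered here, and "the series" means these few. Any claim that something is new, unique, unknown or untested is made for them only; others in the source may bear on it.

Of the compounds shown here, three have been measured in an assay on isolated protein for displacement of a labelled ligand from metabotropic glutamate receptor 5 (Homo sapiens), with a stated time of 60 min, tested at 1 uM; on this read-out lower numbers stand for less inhibition and higher numbers for more inhibition at the one concentration tested (going by the name of the read-out). Compound 1 `CC1CCN(c2c(S(=O)(=O)c3cc(Cl)cc(Cl)c3)cnc3ccc(Cl)cc23)CC1` gives 88%. Compound 2 `COc1ccc(S(=O)(=O)c2cnc3cc(F)ccc3c2N2CCC(C)CC2)cc1OC` gives 83%, the second highest of the three numbers; the gap to compound 1 lies within the scatter, so no order between the two can be read. Compound 3 `O=S(=O)(c1cccc(F)c1)c1cnc2cc(Cl)ccc2c1N1CCC(CO)CC1` gives 71%, which stands beyond the scatter below compound 2.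

The next compound, compound 4 `CC1CCN(c2c(S(=O)(=O)c3ccc(F)cc3)cnc3cc(F)ccc23)CC1`, has not yet been measured in this assay . Relative to compound 2 the structural change is 4-fluorophenyl in place of 3,4-dimethoxyphenyl on a sulfonyl sulfur. Going by the values given here, no pair of measured compounds differs in exactly one place, so no measured step can be carried over. Among the compounds with values here, compound 1 and compound 3, which carry other aryl groups on the sulfonyl sulfur together with other substitution elsewhere, give numbers in this assay of which the one for compound 1 lies within the scatter of compound 2 and the one for compound 3 lies beyond the scatter below it.

The step from compound 2 to compound 4 is expected to be small, most likely a slight decrease or none beyond the scatter, a number 5 percentage points lower from compound 2 to compound 4 (within the scatter). Compound 4 is therefore estimated at 78%, with a range from 62% to 90%.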

Compound 4, a percentage reported as inhibition, at one concentration (the size of the read-out at that concentration, not a potency): 74.5%
Compound 4: middle estimate off by 3.5 percentage points, on the high side; the range from low to high includes it.
By their numbers in this assay, from the lowest: compounds 3, 4, 2 and 1 (each within the scatter of the next, the first and the last beyond it).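

In this assay the series now has its first reading of a single change, made on a sulfonyl sulfur whose other neighbour is an aromatic carbon: 4-fluorophenyl in place of 3,4-dimethoxyphenyl gives a number 8.5 percentage points lower from compound 2 to compound 4 (within the scatter). The earlier compounds shown here could not show this, as none of them formed a pair differing in one place; here, 3,4-dimethoxyphenyl with 10 heavy atoms and 2 hydrogen-bond acceptors gives way to 4-fluorophenyl with 7 heavy atoms and 0 hydrogen-bond acceptors, with the read-out staying within the usual scatter, so this one exchange at this position gives no readable difference. No measurement on hand bears on why the step came out this way.

Compound 1 and compound 3 each differ from compound 2 and from compound 4 in more than one place, so the separate contribution of their sulfonyl aryl groups stays unresolved. Also open, from the compounds shown here alone, is how this assay would respond to an aryl group on the sulfonyl sulfur carrying an amine or a carboxylic acid, and with a single tested concentration, potency across the series remains undefined.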